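Swapping the amide substituent for a trifluoromethylsulfonyl group

The source may report more compounds than this note shows. Statements on the series, on what has been measured and on what is new or still open speak of the compounds shown alone.

Measured compounds in an ADME assay on MT4 cells (Homo sapiens) for cytotoxicity, read by MTT assay, with a stated time of 5 days; on this read-out lower numbers stand for higher toxicity in this test and higher numbers for lower toxicity in this test:
- compound 1 `Cc1cc(C)cc(S(=O)(=O)c2c(C(=O)N[C@@H]3CCNC3)[nH]c3ccc(Cl)cc23)c1`: 37300 nM
- compound 2 `Cc1cc(C)cc(S(=O)(=O)c2c(C(=O)N[C@H]3CCNC3)[nH]c3ccc(Cl)cc23)c1`: 10000 nM
- compound 3 `Cc1cc(C)cc(S(=O)(=O)c2c(C(=O)NC3CN(Cc4n[nH]c(=O)n4C)C3)[nH]c3ccc(Cl)cc23)c1`: 25200 nM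

Compound 1 gives the highest number of the three in this assay. Its nearest neighbour is compound 3, a 1.5-fold lower number from compound 1 to compound 3 (0.17 log units; within the scatter), and its furthest is compound 2, a 3.7-fold lower number from compound 1 to compound 2 (0.57 log units; beyond the scatter); that last step rests on (the fact that compounds 1 and 2 differ only in the configuration as drawn).

Compound 4 `Cc1cc(C)cc(S(=O)(=O)c2c(C(=O)NS(=O)(=O)C(F)(F)F)[nH]c3ccc(Cl)cc23)c1` carries a different group on the amide-type nitrogen of the shared core: (trifluoromethyl)sulfonyl in place of pyrrolidin-3-yl on an amide-type nitrogen.

Among the measured compounds shown here, no measured step exchanges this nitrogen substituent for a group without a ring, so none bears on it directly. The closest comparison is the swap of one ring-bearing group for another on the same nitrogen, a 1.5-fold lower number from compound 1 to compound 3 (0.17 log units; within the scatter), which stays within the scatter, and a 2.5-fold higher number from compound 2 to compound 3 (0.40 log units; beyond the scatter), which is modest. The earlier changes at this position therefore moved the read-out little, and a similarly small step is expected here, in no particular direction beyond the scatter.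

Compound 4 is thus expected to give about 30000 nM, within a range of 10000 nM to 90000 nM, which corresponds to an estimated step of a 1.2-fold lower number from compound 1 to compound 4 (0.09 log units; within the scatter).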

Compound 4, half-maximal cytotoxic concentration: 141000 nM
Estimate against measurement, compound 4: 4.7-fold (0.67 log units) below; measured number above the stated range.
By their numbers in this assay, from the lowest: compound 2; then compounds 3 and 1 (each within the scatter of the next); then compound 4.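

Replacing pyrrolidin-3-yl with (trifluoromethyl)sulfonyl on the amide-type nitrogen raises the number in this assay: the change gives a 3.8-fold higher number from compound 1 to compound 4 (0.58 log units; beyond the scatter) and also a 14-fold higher number from compound 2 to compound 4 (1.15 log units; beyond the scatter) in the same direction, so it holds for both drawn configurations of the pyrrolidin-3-yl group. The replacement of the larger ring-bearing group of compound 3 points the same way, with a 5.6-fold higher number from compound 3 to compound 4 (0.75 log units; beyond the scatter) as its step, and since a higher number stands for lower toxicity in this test, compound 4 is the least toxic of the four here, and this position can move the read-out further than the earlier swaps of one ring-bearing group for another showed. Nothing available explains why this group moves the number in this way.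

On these data alone, whether a methylsulfonyl group on the same nitrogen would give a similar number remains open, and that comparison would help separate the part played by the sulfonyl from the part played by the trifluoromethyl. Also open, as far as these compounds go, is where an open-chain amine such as 2-aminoethyl would fall, which would show whether losing the ring alone shifts the number.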